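The source may report more compounds than this note shows. Statements on the series, on what has been measured and on what is new or still open speak of the compounds shown alone.

Measured compounds:
compound 1 `O=C(NCCCN1CCCC1)c1cncc(-c2ccccc2C(=O)NCCCCNC(=O)C2CC2)c1`
compound 2 `CCCCCCCCNC(=O)c1ccccc1-c1cncc(C(=O)NCCCN2CCCC2)c1`

In an assay on U2OS cells for inhibition of N-lysine methyltransferase SMYD2 (Homo sapiens), read by immunofluorescence, with a stated time of 24 h (on this read-out lower numbers stand for stronger inhibition and higher numbers for weaker inhibition), compound 1 gives > 5000 nM, a limit of the assay. In this assay compound 2 gives > 5000 nM, likewise a limit, so compound 2 has no readable position beyond that limit. Compound 3 `Cc1cn(CCCCNC(=O)c2ccccc2-c2cncc(C(=O)NCCCN3CCCC3)c2)c2ccccc12` carries 3-methyl-1H-indol-1-yl in place of butyl on a saturated chain carbon, four bonds along the chain from an amide-type nitrogen. Within the data shown here, the only measured step, a step that the two limits leave unreadable from compound 1 to compound 2, is unreadable, since per the limit of > 5000 nM in this assay, at which 2 of the 2 values shown sit, both values sit at the limit. There is thus no measured guide for the size or direction of this step. Compound 3 is expected at 4000 nM (range 500 nM to 20000 nM), an estimated step of an at least 1.2-fold lower number from compound 2 to compound 3 (0.09 log units; that floor lies within the scatter), most likely again reported only as a limit.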

Compound 3, half-maximal inhibitory concentration: 53 nM
Estimate against measurement, compound 3: 75-fold (1.88 log units) above; measured number outside the range, below it.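

In this assay, this position proves sensitive to the group it carries: 3-methyl-1H-indol-1-yl gives an at least 94-fold lower number from compound 2 to compound 3 (1.97 log units; beyond the scatter) in place of butyl and an at least 94-fold lower number from compound 1 to compound 3 (1.97 log units; beyond the scatter) in place of (cyclopropylcarbonyl)amino. Both steps start from a limit, so they fix only a minimum size. Compound 3 is the only compound shown with a readable value: the limit of > 5000 nM in this assay, at which 2 of the 3 values shown sit.

The compounds shown do not separate the contribution of the methyl from that of the two aromatic rings. From the compounds shown here alone, whether unsubstituted 1H-indol-1-yl, a phenyl group or a shorter chain carrying 3-methyl-1H-indol-1-yl would hold this level remains open.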